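Carbamate chain length on a selenocyanate aryl core

This account rests on a few compounds, and the source may have more. Where it says the series, first, only, none or still open, it means among the compounds named here.

Of the compounds shown here, two have numbers so far. Compound 1 `CCCOC(=O)Nc1ccc([Se]C#N)cc1` is the propyl carbamate of the shared core; in a functional assay on CCRF-CEM cells (Homo sapiens) for cytotoxicity, read by MTT assay, with a stated time of 72 h (a higher number here means a weaker inhibitor of growth, a lower number a stronger inhibitor of growth), compound 1 gives 38400 nM. Compound 2 `N#C[Se]c1ccc(NC(=O)Oc2ccc(Cl)cc2)cc1` carries a chlorophenyl carbamate instead; in this assay compound 2 gives 45100 nM. Compound 1 has the lower of the two numbers, but the gap to compound 2 lies within the scatter, so the two values show no difference that can be read as an order.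

The step under consideration goes from compound 1 to compound 3 `CCCCCCOC(=O)Nc1ccc([Se]C#N)cc1`. The change is propyl in place of hydrogen on a saturated chain carbon, three bonds along the chain from an oxygen next to a carbonyl group, which read one bond further out is propyl to hexyl. Nothing measured in the series connects this kind of change to a step in this assay, so the expectation rests on the two values alone and on the plain size of the added chain.

Compound 3 is expected to give a somewhat lower number than compound 1, a step of a 1.5-fold lower number from compound 1 to compound 3 (0.19 log units; within the scatter) that may not exceed the scatter. The estimate for compound 3 in this assay is 25000 nM, with a range from 10000 nM to 60000 nM.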

Compound 3, concentration for total growth inhibition: 46200 nM
Beside the measured number, compound 3's estimate is 1.8-fold (0.27 log units) below it, and the stated range covers the measured number.
By their numbers in this assay, from the lowest: compounds 1, 2 and 3 (each within the scatter of the next).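

In this assay the change from propyl to hexyl on the carbamate chain gives a 1.2-fold higher number from compound 1 to compound 3 (0.08 log units; within the scatter), so this step offers no difference that can be read as an order. Among these compounds, it is the first step at this place, on a saturated chain carbon, three bonds along the chain from an oxygen next to a carbonyl group, and the earlier compounds gave no reading of chain length at all. For the pair of propyl and hexyl, then, the added propyl leaves the number within the scatter of compound 1, and no measurement on hand bears on the reason for this.

Open, on these data alone, is whether a chain shorter than propyl, such as methyl, or a chain longer than hexyl, such as decyl or dodecyl, would give a step beyond the scatter, since two chain lengths cannot define a trend. Also open, as far as these compounds go, is how a branched group such as isopropyl, or a carbamate chain carrying an amine or a carboxylic acid, would read in this assay against compound 1.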